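A few compounds are considered here, and "the series" means these few. Any claim that something is new, unique, unknown or untested is made for them only; others in the source may bear on it.

Compound 1 `CCN(CC)CN1C(=O)/C(=N/NC(N)=S)c2ccccc21` opens the series; in an ADME assay on HeLa cells (Homo sapiens) for cytotoxicity (on this read-out higher numbers stand for lower toxicity in this test and lower numbers for higher toxicity in this test), compound 1 gives > 100000 nM, a limit of the assay rather than a number. For the measured compounds named here, compound 2 `CCN(CC)CN1C(=O)/C(=N/NC(=S)Nc2ccc(C)cc2)c2ccccc21` carries 4-methylphenyl in place of hydrogen on an amide-type nitrogen, and in this assay compound 2 gives 10700 nM, the only number among the three values shown. Compound 3 `CCN(CC)CN1C(=O)/C(=N/NC(=S)Nc2ccc(C)cc2)c2cc(Cl)ccc21` adds chloro on an aromatic carbon of the shared core. In this assay compound 3 gives > 100000 nM, again a limit. The two measured steps, an at least 9.3-fold lower number from compound 1 to compound 2 (0.97 log units; beyond the scatter) and an at least 9.3-fold higher number from compound 2 to compound 3 (0.97 log units; beyond the scatter), both run up against (the limit of > 100000 nM in this assay, at which 2 of the 3 values shown sit). Compound 4 `CCN(CC)CN1C(=O)/C(=N/NC(=S)Nc2ccc(OC)cc2)c2ccccc21` differs from compound 2 by methoxy in place of methyl on an aromatic carbon. Neither measured step concerns this change, so no step beyond the scatter is expected. Compound 4 is estimated at 10700 nM, between 4000 nM and 30000 nM, a step of no change at the digits printed from compound 2 to compound 4 (within the scatter).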

Compound 4, half-maximal cytotoxic concentration: > 100000 nM
Compound 4 gave a limit, no number; the forecaster's own chance of this, stated with the estimate: 15%; at least 9.3-fold (0.97 log units) between middle value and limit.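

In this assay, methoxy in place of methyl on the aromatic carbon para to a large group brings an at least 9.3-fold higher number from compound 2 to compound 4 (0.97 log units; beyond the scatter), so this single change is enough to lift the read-out, which 4-methylphenyl alone had lowered. Compound 4 gives a limit and not a number, and its step from compound 1 cannot be read, since both values are limits. Compound 2 thus remains the only compound with a number: the limit of > 100000 nM in this assay, at which 3 of the 4 values shown sit.

On these data alone, whether an amine, a carboxylic acid or an ethyl group at this position would give a number remains open. So does the effect of methoxy in place of methyl when chloro sits on the shared core.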